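Propyl in Place of 1H-Imidazol-2-yl in Compound 4

A few compounds are considered here, and "the series" means these few. Any claim that something is new, unique, unknown or untested is made for them only; others in the source may bear on it.

Compound 1, `Cc1ccc2c(NCc3ccc(NC(=O)C4CCN(Cc5ncc[nH]5)CC4)cc3)nc(N(C)C)nc2c1`, gives > 20000 nM in a functional assay on SV5A8 cells (Homo sapiens) for cytotoxicity (a higher number here means a weaker inhibitor, a lower number a stronger inhibitor), which is a limit.
Compound 2, `Cc1ccc2c(NCc3ccc(NC(=O)C4CCN(C)CC4)cc3)nc(N(C)C)nc2c1`, gives > 17300 nM in this assay, which is a limit.
Compound 3, `CCNc1nc(NCc2ccc(NC(=O)C3CCN(Cc4ccccc4)CC3)cc2)c2ccc(C)cc2n1`, gives > 2140 nM in this assay, which is a limit.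

Among the compounds with values here, compound 1 stands at a limit, and the two further values shown are limits too, so no compound can be ranked against another. Compound 4, `CCCCN1CCC(C(=O)Nc2ccc(CNc3nc(N(C)C)nc4cc(C)ccc34)cc2)CC1`, differs from compound 1 in one place: propyl in place of 1H-imidazol-2-yl on a saturated chain carbon bound to an amine nitrogen in a ring. Within the data shown here, the only measured step at the same place is a step that the two limits leave unreadable from compound 1 to compound 2, which the two limits leave unreadable; the limit of > 20000 nM in this assay, at which 1 of the 3 values shown sits, and the limit of > 17300 nM in this assay, at which 1 of the 3 values shown sits, are all that these two compounds show. Compound 4 is therefore expected to sit at a limit as well, with a step that the limit leaves unreadable from compound 1 to compound 4 not beyond the scatter. The estimate for compound 4 is 30000 nM, between 10000 nM and 100000 nM.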

Compound 4, half-maximal inhibitory concentration: > 10500 nM
Compound 4: a limit, no number; the forecaster's own chance of this, stated with the estimate: 85%; the middle value is on the limit's open side.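

Compound 4 gives > 10500 nM in this assay, which is a limit, so its steps from compound 1 and from compound 2 cannot be read. The compounds shown leave open whether changing the group on the amine nitrogen in a ring alters the read-out in this assay at all.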